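Swapping the amide ring at a clearance limit

This account rests on a few compounds, and the source may have more. Where it says the series, first, only, none or still open, it means among the compounds named here.

In an ADME assay (liver) for metabolic stability, with Liver microsome (Homo sapiens) as the target, using microsomes (on this read-out higher numbers stand for fast clearance and lower numbers for slow clearance), compound 2 `Cc1ccc(NC(=O)c2cc(Oc3cnc(C(=O)N(C)C)cn3)c3cc(C)oc3c2)nc1` gives < 10.6 mL/min/kg, which is a limit and not a number. Compound 1 `Cc1cc2c(Oc3cnc(C(=O)N4CC(C)C4)cn3)cc(C(=O)Nc3cnccn3)cc2o1` also carries pyrazin-2-yl and gives < 9.6 mL/min/kg, likewise a limit. Compound 3 `Cc1cc2c(Oc3cnc(C(=O)N(C)C)cn3)cc(C(=O)Nc3cnccn3)cc2o1` differs from compound 2 by one change: pyrazin-2-yl in place of 5-methylpyridin-2-yl on an amide-type nitrogen, with pyrazin-2-yl in place of 5-methylpyridin-2-yl on an amide-type nitrogen. Going by the values given here, no measured pair shows this swap alone, so only a size beyond the scatter can be ruled unlikely, not excluded. The expected step that the limit leaves unreadable from compound 2 to compound 3 stays within the scatter in this assay. For compound 3 the estimate is 8 mL/min/kg, with an expected range of 4 mL/min/kg to 13 mL/min/kg.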

Compound 3, clearance: 15 mL/min/kg
The estimate for compound 3 lay 1.9-fold (0.27 log units) below the measured number, outside the stated range (above it).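

Compound 3 gives a true number in this assay, whereas the two other compounds give only limits. On the amide-type nitrogen, pyrazin-2-yl in place of 5-methylpyridin-2-yl gives an at least 1.4-fold higher number from compound 2 to compound 3 (0.15 log units; that floor lies within the scatter), and on the carbonyl carbon, dimethylamino in place of 3-methylazetidin-1-yl gives an at least 1.5-fold higher number from compound 1 to compound 3 (0.19 log units; that floor lies within the scatter). Both steps are floors and not full sizes, and the first rests on a limit for compound 2: the limit of < 10.6 mL/min/kg in this assay, at which 1 of the 3 values shown sits.

Going by these compounds, whether either swap truly moves clearance beyond the scatter stays open. On these data alone, how a ring carrying an amine or a carboxylic acid on this amide-type nitrogen would read in this assay is also open.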